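This account rests on a few compounds, and the source may have more. Where it says the series, first, only, none or still open, it means among the compounds named here.

Three amides that share one core have been tested in a functional assay on MDA-MB-231 cells (Homo sapiens) for antiproliferative activity, read by MTT assay, with a stated time of 24 h; a lower number here means a stronger inhibitor, a higher number a weaker inhibitor: compound 1 (`CCCCc1oc2ccccc2c1C(=O)c1ccc(OCC(=O)NC(C)C)cc1`), compound 2 (`CCCCc1oc2ccccc2c1C(=O)c1ccc(OCC(=O)N2CCOCC2)cc1`) and compound 3 (`CCCCc1oc2ccccc2c1C(=O)c1ccc(OCC(=O)Nc2ccccc2)cc1`). Compound 1 gives > 50000 nM, which is a limit of the assay and not a number. Compound 2 gives > 50000 nM, again a limit. Compound 3 gives > 50000 nM, also a limit, so it has no measured potency to start from, and neither do the other two. The whole set is summed up as the limit of > 50000 nM in this assay, at which 3 of the 3 values shown sit.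

Compound 4 (`CCCCc1oc2ccccc2c1C(=O)c1ccc(OCC(=O)Nc2cccc(OC)c2)cc1`) follows from compound 3 by one change, methoxy in place of hydrogen on an aromatic carbon, so that phenylcarbamoyl becomes (3-methoxyphenyl)carbamoyl. The nearest evidence comes from changes at the same amide nitrogen, a step that the two limits leave unreadable from compound 1 to compound 3 and a step that the two limits leave unreadable from compound 2 to compound 3, along with a step that the two limits leave unreadable from compound 1 to compound 2. For the measured compounds named here, none of these has a readable size, so they offer no measured effect to carry over, and no earlier compound in this assay carries this methoxy group. The expectation therefore rests on compound 3 and its limit of > 50000 nM. The expected change is a number no higher from compound 3 to compound 4 (the limit leaves the size open), with no direction that can be predicted and most likely no readable shift. Compound 4 is estimated at 50000 nM, with an expected range from 20000 nM to 100000 nM.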

Compound 4, half-maximal inhibitory concentration: > 50000 nM
Compound 4: a limit, no number; the forecaster's own chance of this, stated with the estimate: 70%; the middle value lies on the limit itself.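

Compound 4 gives > 50000 nM in this assay, which is a limit and not a number. For the compounds shown here, no step among compound 1, compound 2, compound 3 and compound 4 can therefore be read. The compounds shown leave open what potency, if any, an amide on this shared core would reach, and how these amides would rank against one another: the limit of > 50000 nM in this assay, at which 4 of the 4 values shown sit.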